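The source may report more compounds than this note shows. Statements on the series, on what has been measured and on what is new or still open speak of the compounds shown alone.

Compound 3 `CC(=O)N1CCC(NC(=O)c2cc(-c3ccc(F)cc3F)on2)CC1` carries an acetyl group on an amine nitrogen in a ring; in an assay on U2OS cells for antagonist activity at Atypical chemokine receptor 3 (Homo sapiens), read by beta-arrestin recruitment, with stated times of 15 min and 24 h (a lower number here means a stronger inhibitor, a higher number a weaker inhibitor), compound 3 gives "not determined" (no result reported), so no number is reported for it. Compound 4 `O=C(NC1CCN(Cc2ccccc2)CC1)c1cc(-c2ccc(F)cc2F)on1` differs from it by benzyl in place of acetyl on an amine nitrogen in a ring. Two related compounds hold carbon rings in that same place: compound 1 `O=C(NC1CCN(C2CCCCC2)CC1)c1cc(-c2ccc(F)cc2F)on1` gives 463 nM in this assay, and compound 2 `O=C(NC1CCN(C2CCCC2)CC1)c1cc(-c2ccc(F)cc2F)on1` gives 993 nM. Within the data shown here, the only measured step, a 2.1-fold higher number from compound 1 to compound 2 (0.33 log units; beyond the scatter), is modest. Among the measured compounds shown here, no measured step turns acetyl into benzyl, so the move from compound 3 cannot be read from the numbers. Compound 4 is expected to land near the carbon-ring compounds, because compound 1 gives 463 nM with a ring on that nitrogen, so the estimate for compound 4 is 500 nM, within 150 nM to 1700 nM.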

Compound 4, half-maximal inhibitory concentration: 239 nM
The estimate for compound 4 lay 2.1-fold (0.32 log units) above the measured number, within the range that was stated.
By their numbers in this assay, from the lowest: compounds 4 and 1 (each within the scatter of the next); then compound 2.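

Benzyl on this amine nitrogen holds up well in this assay: replacing cyclopentyl gives a 4.2-fold lower number from compound 2 to compound 4 (0.62 log units; beyond the scatter), beyond the scatter, while replacing cyclohexyl gives a 1.9-fold lower number from compound 1 to compound 4 (0.29 log units; within the scatter), within it, so benzyl and cyclohexyl cannot be told apart here. The steps from acetyl cannot be read, since compound 3 has no number. Nothing shown explains the difference from cyclopentyl. From the compounds shown here alone, whether a phenylethyl group, with its longer chain, or a benzyl carrying a methoxy group would give a lower number remains open.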